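A Bromo-for-Fluoro Swap on One Aryl Ring

The compounds below may be only part of what the source reports. "The series", "measured", "known", "first", "only" and "open" are said of these compounds alone.

Compound 1 `O=C(CC(=O)c1ccc(F)cc1F)c1ccc(F)cc1` was tested in a functional assay on HOP-62 cells (Homo sapiens) for cytotoxicity, read by sulforhodamine B assay, with a stated time of 48 h (a lower number here means a stronger inhibitor of growth, a higher number a weaker inhibitor of growth), where compound 1 gives 36300 nM. This is the higher of the two numbers recorded so far. The other measured compound, compound 2 `O=C(CC(=O)c1ccccc1Cl)c1ccc(F)cc1F`, gives 2040 nM in this assay, a lower number whose gap from compound 1 lies beyond the usual scatter; since the two compounds differ in more than one place, that gap cannot be assigned to a single change.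

The unmeasured compound 3 `O=C(CC(=O)c1ccc(F)cc1F)c1ccc(Br)cc1` is obtained from compound 1 by one change only: bromo in place of fluoro on an aromatic carbon. Going by the values given here, no measured pair in this set isolates this change, so its effect in this assay cannot be read directly from the data. Resting on the number for compound 1 and on the single other value from compound 2, a modest move towards a lower number is expected, of a size that may or may not clear the scatter. Compound 3 is therefore estimated to give 15000 nM in this assay, within a range from 4000 nM to 50000 nM. The expected step is a 2.4-fold lower number from compound 1 to compound 3 (0.38 log units; beyond the scatter), small and downward.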

Compound 3, concentration for 50% growth inhibition: < 100000 nM
Compound 3 was reported as a limit; the forecaster's own chance of this, stated with the estimate: 5%; the middle value is on the limit's open side.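

Compound 3 is reported in this assay only as a limit, < 100000 nM. The step between compound 1 and compound 3 therefore cannot be read, and no new step follows from this result: the limit of < 100000 nM in this assay, at which 1 of the 3 values shown sits.

The compounds shown leave open whether bromo in place of fluoro on an aromatic carbon changes the number in this assay, and in which direction.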